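Working notes: piperidin-1-yl step from compound 2

This account rests on a few compounds, and the source may have more. Where it says the series, first, only, none or still open, it means among the compounds named here.

Measured so far in an ADME assay on microsomes from liver (Mus musculus) for metabolic stability, read by LC-MS, with a stated time of 40 min, tested at 0.5 uM (on this read-out lower numbers stand for slow clearance and higher numbers for fast clearance), are two compounds:
- compound 1 `CC(C)(O)CNc1ccc(C(=O)Nc2cccc(S(=O)(=O)C3CCCC3)n2)c(N2CCC3(CC2)CC3)c1` gives > 399 mL.min-1.g-1 as a limit
- compound 2 `CC1(C)CCN(c2ncccc2C(=O)Nc2cccc(S(=O)(=O)C3CCCC3)c2)CC1` gives > 399 mL.min-1.g-1 as a limit

Compound 2 stands at the end of the range, with > 399 mL.min-1.g-1 being a limit and not a number. Going by the values given here, the series so far offers only the limit of > 399 mL.min-1.g-1 in this assay, at which 2 of the 2 values shown sit, and no measured step between compounds.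

Compound 3 `O=C(Nc1cccc(S(=O)(=O)C2CCCC2)c1)c1cccnc1N1CCCCC1` differs from compound 2 in one place: piperidin-1-yl in place of 4,4-dimethylpiperidin-1-yl on an aromatic carbon with piperidin-1-yl in place of 4,4-dimethylpiperidin-1-yl on an aromatic carbon.

In this assay a small step toward lower numbers is expected, or none beyond the scatter. The estimated step of an at least 1.3-fold lower number from compound 2 to compound 3 (0.12 log units; that floor lies within the scatter) is measured against a limit and stays rough. For compound 3 the expected value is 300 mL.min-1.g-1 with an estimated range of 130 mL.min-1.g-1 to 480 mL.min-1.g-1 and a fair chance of another limit reading.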

Compound 3, intrinsic clearance in microsomes: > 399 mL.min-1.g-1
Compound 3 ended at the assay's limit; the forecaster's own chance of this, stated with the estimate: 45%; middle value at least 1.3-fold (0.12 log units) away from the limit.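

No step from compound 2 to compound 3 can be read in this assay, since both compounds sit at one limit, which is not a number: the limit of > 399 mL.min-1.g-1 in this assay, at which 3 of the 3 values shown sit.

The compounds shown leave open how piperidin-1-yl and 4,4-dimethylpiperidin-1-yl compare, and whether any compound of the series gives a number rather than a limit.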